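The compounds below may be only part of what the source reports. "The series", "measured", "known", "first", "only" and "open" are said of these compounds alone.

Of the compounds shown here, two have so far been measured in a functional assay on HepG2 cells (Homo sapiens) for inhibition, read by MTT assay, with a stated time of 24 h; a lower number here means a stronger inhibitor, a higher number a weaker inhibitor. Compound 1 `O=[N+]([O-])c1cccc(CNc2cc(Br)cc3[nH]ncc23)c1` gives 23600 nM, while compound 2 `Cc1ccc(CNc2cc(C(F)(F)F)cc3[nH]ncc23)c([N+](=O)O)c1` gives 540 nM. Compound 2 therefore holds the lower of the two numbers, and the gap between the pair lies beyond the usual scatter of repeat measurements. The two differ in more than one place, so that gap says nothing about any single change.

The next molecule, compound 3 `CS(=O)(=O)c1ccc(CNc2cc(C(F)(F)F)cc3[nH]ncc23)c([N+](=O)O)c1`, is compound 2 with one alteration: methylsulfonyl in place of methyl on an aromatic carbon. Within the data shown here, no measured pair shows what this swap does, so any forecast is uncertain. Among the measured compounds shown here, the starting point, compound 2 at 540 nM, is the better of only two values, so a moderate rise in the number, meaning a somewhat weaker inhibitor, seems more likely than a further fall. A result within the scatter would not be surprising. The expected change is a 2.2-fold higher number from compound 2 to compound 3 (0.35 log units; beyond the scatter). Compound 3 is estimated at 1200 nM, with a likely range from 250 nM to 6000 nM.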

Compound 3, half-maximal inhibitory concentration: > 20000 nM
Compound 3 was reported as a limit (the forecaster's own chance of this, stated with the estimate: 5%); at least 16-fold (1.22 log units) between middle value and limit.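

Methylsulfonyl in place of methyl on this aromatic carbon, para to a large group, is the first single change that can be read in this assay, and it gives an at least 37-fold higher number from compound 2 to compound 3 (1.56 log units; beyond the scatter), so the swap leaves a much weaker inhibitor. The result for compound 3 is a limit of the assay and not a number: the limit of > 20000 nM in this assay, at which 1 of the 3 values shown sits. The earlier compounds shown here differed in more than one place, whereas this pair shows that the group at this one carbon can by itself decide much of the activity, with one heavy atom replaced by four, two of them hydrogen-bond acceptors.

As far as these compounds go, this single swap cannot separate the part played by the larger size of the group from that of its hydrogen-bond acceptors, and the distance of compound 3 beyond its limit remains unknown. Comparisons with a methoxy group, a chlorine atom or an amine on the same carbon would show how narrow the demand at this position is, and the shown pairs also leave open whether the same swap would have a similar effect with bromine in place of trifluoromethyl on the shared core.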